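A few compounds are considered here, and "the series" means these few. Any claim that something is new, unique, unknown or untested is made for them only; others in the source may bear on it.

In a functional assay on L02 cells (Homo sapiens) for inhibition, read by Griess assay, with stated times of 1 h and 24 h (a higher number here means a weaker inhibitor, a lower number a stronger inhibitor), compound 1 `COc1cc(/C=C/c2nc(NC3CC3)c3sccc3n2)cc(OC)c1OC` gives > 1000000 nM as a limit of the assay, not a number. Compound 2 `CCN1CCN(c2nc(/C=C/c3cc(OC)c(OC)c(OC)c3)nc3ccsc23)CC1` gives > 1000000 nM as a limit too. Compound 3 `COc1ccc(CNc2nc(/C=C/c3cc(OC)c(OC)c(OC)c3)nc3ccsc23)cc1` gives > 1000000 nM as a limit as well. Compound 3 therefore has no exact standing among the three, since the whole record so far is the limit of > 1000000 nM in this assay, at which 3 of the 3 values shown sit, and that allows no ranking.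

Compound 4 `COc1cc(/C=C/c2nc(NC(C)C)c3sccc3n2)cc(OC)c1OC` differs from compound 3 by isopropyl in place of 4-methoxybenzyl on a nitrogen on an aromatic ring and in words this puts isopropyl in place of 4-methoxybenzyl on a nitrogen on an aromatic ring. The measured step that swaps a group on that same nitrogen is a step that the two limits leave unreadable from compound 1 to compound 3 and the two others are a step that the two limits leave unreadable from compound 1 to compound 2 and a step that the two limits leave unreadable from compound 2 to compound 3 so none of them offers a size to carry over. From these steps no particular size or direction of change can be expected in this assay and the likeliest reading is another limit. The expected outcome is a number no higher from compound 3 to compound 4 (the limit leaves the size open) with no direction foreseen. For compound 4 the estimated value is 1000000 nM with an expected range from 300000 nM to 3000000 nM as the best guess available.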

Compound 4, half-maximal inhibitory concentration: > 1000000 nM
Compound 4: no number, only a limit; the forecaster's own chance of this, stated with the estimate: 85%; the middle value sits exactly at the limit.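

In this assay compound 4 gives > 1000000 nM, a limit of the assay and not a number. Its steps to compound 1, compound 2 and compound 3 cannot be read, as all four compounds share one limit: the limit of > 1000000 nM in this assay, at which 4 of the 4 values shown sit.

The compounds shown leave open whether any group on the shared core gives a measurable value in this assay, and how these groups rank.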